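Pyrrolidine ring variation on the shared core

A few compounds are considered here, and "the series" means these few. Any claim that something is new, unique, unknown or untested is made for them only; others in the source may bear on it.

The three measured compounds share the shared core of compound 1 `N#Cc1ccc(-c2ccc(OCCCN3CC[C@H](O)C3)cc2)cc1`, which in an assay on isolated protein for binding affinity to histamine H2 receptor (Homo sapiens) (a higher number here means a weaker inhibitor, a lower number a stronger inhibitor), gives 19100 nM. Compound 2 `CCOC(=O)N1CCN(CCCOc2ccc(-c3cccc(C#N)c3)cc2)CC1` gives 24000 nM in this assay, and compound 3 `N#Cc1ccc(-c2ccc(OCCCN3CCC(N)CC3)cc2)cc1` gives 33900 nM. Compound 1 thus has the lowest of the three numbers, but each of the other two lies within the scatter of it, so no order among them is claimed. Among the compounds with values here, the one single-point step available, a 1.8-fold higher number from compound 1 to compound 3 (0.25 log units; within the scatter), exchanges the whole amine ring and still stays within the scatter.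

Compound 4 `N#Cc1ccc(-c2ccc(OCCCN3CCCC3)cc2)cc1` differs from compound 1 as follows: hydrogen in place of hydroxy on a saturated ring carbon. Within the data shown here, no measured step removes a hydroxy from the amine ring, so the only guidance is indirect: a larger change at the same end of the chain, from compound 1 to compound 3, moved the number little. A step of similar size or none beyond the scatter is therefore expected, a 1.3-fold higher number from compound 1 to compound 4 (0.12 log units; within the scatter). For compound 4 in this assay the expected value is 25000 nM, with a range from 10000 nM to 60000 nM.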

Compound 4, inhibition constant: 67600 nM
The estimate for compound 4 lay 2.7-fold (0.43 log units) below the measured number; measured number outside the range, above it.
By their numbers in this assay, from the lowest: compounds 1, 2, 3 and 4 (each within the scatter of the next, the first and the last beyond it).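

Taking the hydroxy off the saturated ring carbon, two ring bonds from the ring nitrogen, gives the first step in this assay that lies beyond the scatter (a 3.5-fold higher number from compound 1 to compound 4 (0.55 log units; beyond the scatter)), though it remains modest. This position therefore registers a one-atom change, whereas the exchange of one amine ring for another, with the hydroxy absent from both compounds, stays within the scatter (a 2.0-fold higher number from compound 3 to compound 4 (0.30 log units; within the scatter)). Nothing available accounts for the step at this position.

Going by these compounds, whether the same step would follow from a methoxy or an amino group on that ring carbon, or from the opposite configuration of the hydroxy, stays open. Also open, on these data alone, is whether a hydroxy on a piperidine ring, or a longer chain to the amine, would read the same way.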